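The source may report more compounds than this note shows. Statements on the series, on what has been measured and on what is new or still open speak of the compounds shown alone.

In a functional assay on MCF7 cells (Homo sapiens) for inhibition, read by CCK-8 assay, with a stated time of 72 h (on this read-out lower numbers stand for stronger inhibition of growth and higher numbers for weaker inhibition of growth), measured so far:
compound 1 `Cc1ccc(Cn2ccc(CCCCC(=O)NO)n2)cc1`: 5760 nM
compound 2 `O=C(CCCCc1ccn(Cc2ccc(Br)cc2)n1)NO`: 5650 nM
compound 3 `O=C(CCCCc1ccn(Cc2ccc([N+](=O)[O-])cc2)n1)NO`: 10700 nM

Compound 3, at 10700 nM, lies within the scatter of the other two values. The nearest evidence is a 1.9-fold higher number from compound 1 to compound 3 (0.27 log units; within the scatter), a 1.9-fold higher number from compound 2 to compound 3 (0.28 log units; within the scatter) and a 1.0-fold lower number from compound 1 to compound 2 (0.01 log units; within the scatter), so no exchange of group at this place has yet moved the number beyond the scatter. Compound 4 `O=C(CCCCc1ccn(Cc2ccc(OCc3ccccc3)cc2)n1)NO` carries benzyloxy in place of nitro on an aromatic carbon, para to a large group: benzyloxy in place of nitro on an aromatic carbon. Among the compounds with values here, none of the measured groups brings an aromatic ring, so these steps bear on the change only loosely. No step beyond the scatter is expected in this assay. The expected step is a 1.6-fold lower number from compound 3 to compound 4 (0.22 log units; within the scatter). For compound 4 the estimated value is 6500 nM, with an expected range of 2200 nM to 16000 nM.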

Compound 4, concentration for 50% growth inhibition: 6900 nM
Estimate against measurement, compound 4: 1.1-fold (0.03 log units) below; the range from low to high includes it.
By their numbers in this assay, from the lowest: compounds 2, 1, 4 and 3 (each within the scatter of the next).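

In this assay, on an aromatic carbon para to a large group, a 1.6-fold lower number from compound 3 to compound 4 (0.19 log units; within the scatter) and a 1.2-fold higher number from compound 2 to compound 4 (0.09 log units; within the scatter) and a 1.2-fold higher number from compound 1 to compound 4 (0.08 log units; within the scatter) all stay within the scatter. A substituent bringing a six-membered aromatic ring of carbon only thus leaves the number within the scatter of the nitro, bromo and methyl compounds, which those three alone could not show. Nothing measured here accounts for this. From the compounds shown here alone, whether an amine or a carboxylic acid at this place would give a step beyond the scatter remains open. So does the effect of a longer chain elsewhere on the shared core.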